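A few compounds are considered here, and "the series" means these few. Any claim that something is new, unique, unknown or untested is made for them only; others in the source may bear on it.

Compound 2 `O=C(O)c1ccccc1-c1ccc(CCc2ncc(Cc3cccc(F)c3F)[nH]2)cc1` carries a carboxylic acid on one ring and a 2,3-difluorobenzyl group on the other end of the molecule. In an in vitro functional assay on cells for agonist activity at Bombesin receptor subtype-3 (Mus musculus), read by luminescence and calcium flux (on this read-out higher numbers stand for an effect only at larger amounts of compound and lower numbers for an effect already at smaller amounts), compound 2 gives 8 nM. Going by the values given here, only one other compound has been measured so far: compound 1 `O=C(O)c1ccccc1-c1ccc(CCc2ncc(CC3CCCC3)[nH]2)cc1`, which carries a cyclopentylmethyl group in the same place, and in this assay compound 1 gives 7.9 nM. The two numbers sit within the scatter of each other, so no order between them can be read from the data. The step of a 1.0-fold higher number from compound 1 to compound 2 (0.01 log units; within the scatter) shows that swapping a saturated ring for a fluorinated aromatic ring at this point left the read-out essentially unchanged.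

Compound 3 `Cc1ccc(Cc2cnc(CCc3ccc(-c4ccccc4C(=O)O)cc3)[nH]2)cc1` differs from compound 2 in the same region: 4-methylphenyl in place of 2,3-difluorophenyl on a saturated chain carbon bound to an aromatic carbon. Among the compounds with values here, the one step that bears on this position is a 1.0-fold higher number from compound 1 to compound 2 (0.01 log units; within the scatter), and it was within the scatter. No other measured change touches this group. On that basis, the step of a 1.3-fold higher number from compound 2 to compound 3 (0.10 log units; within the scatter) is expected to be small, with no direction beyond the scatter. Compound 3 is therefore estimated at 10 nM, within a range from 3 nM to 35 nM.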

Compound 3, half-maximal effective concentration: 162 nM
Beside the measured number, compound 3's estimate is 16-fold (1.21 log units) below it; the measured number lies above the stated range.
By their numbers in this assay, from the lowest: compounds 1 and 2 (each within the scatter of the next); then compound 3.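

The position on the saturated chain carbon bound to an aromatic carbon turns out to be sensitive to the group it carries: in this assay, 4-methylphenyl in place of 2,3-difluorophenyl gives a 20-fold higher number from compound 2 to compound 3 (1.31 log units; beyond the scatter) and, in place of cyclopentyl, gives a 21-fold higher number from compound 1 to compound 3 (1.31 log units; beyond the scatter) on the same read-out. The earlier match between cyclopentyl and 2,3-difluorophenyl therefore did not mean that any ring is accepted here, as 4-methylphenyl is also a six-membered aromatic ring of carbon only, just like 2,3-difluorophenyl, and yet its number stands well apart. Those shared counts, with no hydrogen-bond donors or acceptors and no net charge on either group, do not separate the two aromatic groups, and no measurement at hand explains the difference.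

The compounds shown leave open whether the higher number comes with the methyl group itself or with the absence of the two fluorines. An unsubstituted phenyl or a 4-fluorophenyl at this place would help to separate those two readings, and a 2,3-dimethylphenyl would show whether methyl groups are tolerated where the fluorines sit in compound 2.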